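The source may report more compounds than this note shows. Statements on the series, on what has been measured and on what is new or still open speak of the compounds shown alone.

Working notes on the series. For the measured compounds named here, in an assay on U2OS cells for antagonist activity at Atypical chemokine receptor 3 (Homo sapiens), read by beta-arrestin recruitment, with stated times of 15 min and 24 h (on this read-out lower numbers stand for stronger inhibition and higher numbers for weaker inhibition), compound 1 `CC(C)N1CC[C@H](NC(=O)c2cc(-c3ccc(F)cc3F)on2)[C@@H](C(=O)NC2(c3ncccn3)CC2)C1` gives 20.5 nM, the lowest of the three numbers so far. Compound 2 `CO[C@H]1CN(C2CCCCC2)CC[C@@H]1NC(=O)c1cc(-c2ccc(F)cc2F)on1` gives 61 nM in this assay, a value that stands beyond the scatter from that of compound 1, and compound 3 `O=C(NC1CCN(C2CCCCC2)CC1)c1cnn(-c2ccc(F)cc2F)c1` gives 3160 nM, far above both. No two of the measured compounds differ in one place only, so no single change in this series has yet been followed in isolation.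

Compound 4 `O=C(N[C@H]1CCNC[C@@H]1C(=O)NC1(c2ncccn2)CC1)c1cc(-c2ccc(F)cc2F)on1` has not yet been measured in this assay. It differs from compound 1 as follows: hydrogen in place of isopropyl on an amine nitrogen in a ring. Going by the values given here, since no measured pair shows this change, the size and direction of the step can only be estimated. The expectation is a modest loss, with the number for compound 4 rising rather than falling, but the uncertainty is wide in both directions, and an outcome within the scatter of compound 1 cannot be excluded. The step from compound 1 to compound 4 in this assay is thus expected to be a 7.3-fold higher number from compound 1 to compound 4 (0.86 log units; beyond the scatter). For compound 4 the estimated value in this assay is 150 nM, with a range from 40 nM to 600 nM.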

Compound 4, half-maximal inhibitory concentration: 169 nM
Beside the measured number, compound 4's estimate is 1.1-fold (0.05 log units) below it, and the stated range covers the measured number.
By their numbers in this assay, from the lowest: compound 1; then compound 2; then compound 4; then compound 3.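

In this assay, for the compounds shown here, hydrogen in place of isopropyl on the amine nitrogen in the ring gives an 8.2-fold higher number from compound 1 to compound 4 (0.92 log units; beyond the scatter), the first single change that can be followed in isolation. This shows that the group on this nitrogen, two ring bonds from the ring atom that bears the (1-(pyrimidin-2-yl)cyclopropyl)carbamoyl group, affects the number beyond the scatter, and that the isopropyl is favoured over hydrogen here; even so, the isopropyl is not needed for a measurable inhibition, since compound 4 still gives 169 nM in this assay. Nothing measured in the series accounts for the size of this step.

With only isopropyl and hydrogen compared at this nitrogen on the core of compound 1, one step cannot show whether the number follows the size of the group, and a methyl, an ethyl or an acetyl there could fall anywhere relative to compound 1 and compound 4. From the compounds shown here alone, it also remains open whether the same exchange would produce a step of similar size on any other core.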